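The compounds below may be only part of what the source reports. "The series", "measured", "known", "first", "only" and "open" are said of these compounds alone.

Measured so far in a functional assay on HepG2 cells (Homo sapiens) for cytotoxicity, read by MTT assay, with a stated time of 72 h; a lower number here means a stronger inhibitor of growth, a higher number a weaker inhibitor of growth:
Compound 1, `CS/C(=N\C(=O)c1ccco1)NC(=O)c1ccco1`, gives > 100000 nM, which is a limit of this assay rather than a number.
Compound 2, `O=C(/N=C(/NC(=O)c1ccco1)[Se]Cc1ccccc1)c1ccco1`, gives 7650 nM.
Compound 3, `CS/C(=N\C(=O)c1cnc2ccccc2c1)NC(=O)c1cnc2ccccc2c1`, gives 57600 nM.

Compound 1 and compound 2 share a core and differ in one place: a group of 8 heavy atoms (7 carbon, 1 selenium; one six-membered aromatic ring of carbon only) in place of a group of 2 heavy atoms (1 carbon, 1 sulfur; no ring), on a carbon with a double bond to nitrogen. This change gives an at least 13-fold lower number from compound 1 to compound 2 (1.11 log units; beyond the scatter), and the step can only be stated as a lower bound because compound 1 sits at the limit of > 100000 nM in this assay, at which 1 of the 3 values shown sits.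

Compound 3 carries a different core; how the two cores differ is not broken down here. Compound 3 stands highest of the two numbers, with compound 2 as its nearest measured neighbour.

Compound 4, `O=C(/N=C(/NC(=O)c1cnc2ccccc2c1)[Se]Cc1ccccc1)c1cnc2ccccc2c1`, has not yet been measured. It differs from compound 3 in exactly the way compound 2 differs from compound 1: a group of 8 heavy atoms (7 carbon, 1 selenium; one six-membered aromatic ring of carbon only) in place of a group of 2 heavy atoms (1 carbon, 1 sulfur; no ring), on a carbon with a double bond to nitrogen. Since the place of the change is the same in both pairs, the same kind of step is expected for compound 4 in this assay, a 12-fold lower number from compound 3 to compound 4 (1.06 log units; beyond the scatter), resting on the step seen from compound 1 to compound 2, an at least 13-fold lower number from compound 1 to compound 2 (1.11 log units; beyond the scatter). Compound 4 is therefore estimated at 5000 nM, with a range from 1500 nM to 20000 nM.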

Compound 4, concentration for 50% growth inhibition: 8540 nM
The estimate for compound 4 lay 1.7-fold (0.23 log units) below the measured number; the measured number falls inside the stated range.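

In this assay, replacing methylsulfanyl with the selenium-carrying group and its aromatic ring on the core of compound 3 gives a 6.7-fold lower number from compound 3 to compound 4 (0.83 log units; beyond the scatter), so the direction of the step seen on the core of compound 1 carries over to this second core. Compound 1 gives > 100000 nM, which is a limit of the assay and not a number. The first step is therefore only a bound, and the data do not show whether the change is worth the same amount on both cores: the same change on two cores in this assay, an at least 13-fold lower number (1.11 log units; beyond the scatter) from compound 1 to compound 2 and a 6.7-fold lower number (0.83 log units; beyond the scatter) from compound 3 to compound 4; the limit leaves it open whether they differ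

From the compounds shown here alone, the selenium and the aromatic ring always enter together in these compounds, so it stays open which of the two goes with the lower numbers, and a simple methyl on selenium or an aromatic ring group on sulfur would separate them. Also open, going by these compounds, is how a longer chain or an amine would behave at this place, and whether the step holds on any core beyond these two.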